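Thymol-type Benzoate Esters: Nitro for Methyl in Glioblastoma Cells

This account rests on a few compounds, and the source may have more. Where it says the series, first, only, none or still open, it means among the compounds named here.

Measured compounds:
compound 1 `CC1=CC[C@H](C(C)C)c2cc(C)c(OC(=O)c3ccc(C)cc3)cc21` — 67.7%
compound 2 `CC1=CC[C@H](C(C)C)c2cc(C)c(OC(=O)c3ccc([N+](=O)[O-])cc3)cc21` — 16.8%
compound 3 `CC1=CC[C@H](C(C)C)c2cc(C)c(OC(=O)c3cccc(C)c3)cc21` — 16.8%

Three esters of a shared core were tested in a functional assay on U-251 cells (Homo sapiens) for antiproliferative activity, read by sulforhodamine B assay, with a stated time of 48 h, tested at 50 uM; a higher number here means more inhibition at the concentration tested (going by the name of the read-out), a lower number less inhibition. Compound 1 gives 67.7%, whereas compound 2 gives 16.8% and compound 3 gives 16.8%. Compound 2 differs from compound 1 by nitro in place of methyl on an aromatic carbon, and that step is a number 50.9 percentage points lower from compound 1 to compound 2 (beyond the scatter). Compound 3 differs from compound 1 by 3-methylphenyl in place of 4-methylphenyl on a carbonyl carbon, giving a number 50.9 percentage points lower from compound 1 to compound 3 (beyond the scatter). Between compound 2 and compound 3 there is no change at the digits printed from compound 2 to compound 3 (within the scatter).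

Compound 4 `CC1=CC[C@H](C(C)C)c2cc(C)c(OC(=O)c3cccc([N+](=O)[O-])c3)cc21` has not yet been measured. It differs from compound 3 by nitro in place of methyl on an aromatic carbon. Among the measured compounds shown here, this is the same kind of change as the one from compound 1 to compound 2, but the place differs: there it was para to a large group, here it is meta to a large group. The step from compound 3 to compound 4 in this assay is estimated as a number 2.8 percentage points lower from compound 3 to compound 4 (within the scatter), much smaller than the earlier one. This rests on compound 3 already standing at 16.8%, level with compound 2, so little room remains for a further fall. Compound 4 is expected to give 14%, with a range from 0% to 40%.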

Compound 4, a percentage reported as inhibition, at one concentration (the size of the read-out at that concentration, not a potency): 44%
Estimate against measurement, compound 4: 30 percentage points below; measured number outside the range, above it.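

In this assay, nitro in place of methyl on an aromatic carbon does not carry over from one ester to the other, and the two steps run in opposite directions: the same change on two cores in this assay, a number 50.9 percentage points lower (beyond the scatter) from compound 1 to compound 2 and a number 27.2 percentage points higher (beyond the scatter) from compound 3 to compound 4, 78.1 percentage points apart, beyond the scatter of two such steps

On the 3-methylphenyl ester, the change gives a number 27.2 percentage points higher from compound 3 to compound 4 (beyond the scatter), and moving the nitro group also counts, with 3-nitrophenyl in place of 4-nitrophenyl giving a number 27.2 percentage points higher from compound 2 to compound 4 (beyond the scatter), while 3-nitrophenyl in place of 4-methylphenyl still leaves a number 23.7 percentage points lower from compound 1 to compound 4 (beyond the scatter). This shows that, among these four esters, the direction of the step depends on where the exchange takes place on the ring, but it does not show why, and one pair on each side, read at a single concentration, gives no rule for other cores.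

The compounds shown leave open whether an amine, a carboxylic acid or a methoxy group at these same places would follow the methyl or the nitro esters. They also leave open whether an amide link in place of the ester would keep these differences.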